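Acetyl for Hydrogen: Expecting the Value of Compound 4

A few compounds are considered here, and "the series" means these few. Any claim that something is new, unique, unknown or untested is made for them only; others in the source may bear on it.

Compound 1, `CCCC[C@@H](/C=C\[C@@H]1OC(=O)C=C[C@@H]1OC(C)=O)OC(C)=O`, gives 5700 nM in a functional assay on HCT-15 cells (Homo sapiens) for cytotoxicity, read by sulforhodamine B assay, with a stated time of 48 h; a lower number here means a stronger inhibitor, a higher number a weaker inhibitor.
Compound 2, `CCCC[C@@H](/C=C\[C@@H]1OC(=O)C=C[C@@H]1O)OC(C)=O`, gives 2300 nM in this assay.
Compound 3, `CCCC[C@H](/C=C\[C@@H]1OC(=O)C=C[C@@H]1O)OC(C)=O`, gives 9500 nM in this assay.

Compound 3 carries the highest number of the three. Compound 1 lies within the scatter of it, while compound 2 sits clearly apart, as a 4.1-fold higher number from compound 2 to compound 3 (0.62 log units; beyond the scatter) shows, a step that rests on the fact that compounds 2 and 3 differ only in the configuration as drawn alone. Compound 4, `CCCC[C@H](/C=C\[C@@H]1OC(=O)C=C[C@@H]1OC(C)=O)OC(C)=O`, differs from compound 3 by acetyl in place of hydrogen on an oxygen on a saturated carbon. Among the measured compounds shown here, the one measured step that bears on this change is a 2.5-fold lower number from compound 1 to compound 2 (0.39 log units; beyond the scatter), run in the opposite direction. Turned around, the step to compound 4 is expected to be a modest rise in the number, a 2.3-fold higher number from compound 3 to compound 4 (0.36 log units; beyond the scatter). Compound 4 is therefore estimated at 22000 nM, within a range of 9000 nM to 55000 nM.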

Compound 4, half-maximal inhibitory concentration: 800 nM
Compound 4: the middle estimate sits 28-fold (1.44 log units) above what was measured; the whole stated range lies above it.
By their numbers in this assay, from the lowest: compound 4; then compound 2; then compounds 1 and 3 (each within the scatter of the next).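

On this oxygen, acetyl in place of hydrogen has no single direction in this assay: it gives a 12-fold lower number from compound 3 to compound 4 (1.07 log units; beyond the scatter), while the same change on the other drawn configuration raises the number, so its outcome here goes with the configuration at the saturated chain carbon: the same change on two cores in this assay, a 2.5-fold lower number (0.39 log units; beyond the scatter) from compound 1 to compound 2 and a 12-fold higher number (1.07 log units; beyond the scatter) from compound 4 to compound 3, 29-fold (1.47 log units) apart, beyond the scatter of two such steps. Inverting that stereocentre with acetyl present gives a 7.1-fold lower number from compound 1 to compound 4 (0.85 log units; beyond the scatter), a direction opposite to the one seen with the free hydroxy group: the fact that compounds 1 and 4 differ only in the configuration as drawn.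

The compounds shown leave open whether this reversal would hold with a benzoyl group on the same oxygen or with a longer chain. They also leave open how the other stereocentres bear on the number.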